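The source may hold more compounds than are shown below. What is called first, only, known or untested is meant among the compounds shown, and "the series" means these compounds.

Measured so far:
compound 1, `N=C(N)c1ccc(-c2ccc(-c3cc(Cl)cc(Cl)c3)s2)s1`, which in a functional assay on A549 cells (Homo sapiens) for inhibition, read by sulforhodamine B assay, with a stated time of 48 h (on this read-out higher numbers stand for weaker inhibition of growth and lower numbers for stronger inhibition of growth), gives 2070 nM;
compound 2, `COc1ccc(-c2ccc(-c3ccc(C(=N)N)o3)o2)cc1`, which in this assay gives 1490 nM.

On these two numbers compound 2 holds the lower one, yet compound 1 sits close to it, and the gap stays within the scatter, so the two cannot be ranked against each other. For the measured compounds named here, no step between measured compounds that differ in one place is available from this pair. Compound 3, `N=C(N)c1ccc(-c2ccc(-c3ccc(Cl)cc3)o2)o1`, is not yet measured. It differs from compound 2 by chloro in place of methoxy on an aromatic carbon. Going by the values given here, with no comparable step to draw on, the size of the change from compound 2 to compound 3 in this assay is open; the expectation is that it stays within the scatter, with no direction preferred. The number expected for compound 3 in this assay is therefore 1500 nM, within a range of 500 nM to 4500 nM. That estimate corresponds to an expected step of a 1.0-fold higher number from compound 2 to compound 3 (0.00 log units; within the scatter).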

Compound 3, concentration for 50% growth inhibition: 1980 nM
The estimate for compound 3 lay 1.3-fold (0.12 log units) below the measured number; measured number inside the range.
By their numbers in this assay, from the lowest: compounds 2, 3 and 1 (each within the scatter of the next).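

In this assay, for the compounds shown here, the exchange of methoxy for chloro on an aromatic carbon, para to a large group, gives a 1.3-fold higher number from compound 2 to compound 3 (0.12 log units; within the scatter) and this is the first comparison here in which only one place differs. At this place on the six-membered aromatic ring of carbon only, the read-out does not separate methoxy, with its hydrogen-bond acceptor, from chloro, which has none. No measured property bears on this result, so nothing can be said about what lies behind it.

From the compounds shown here alone, whether a carboxylic acid, an amine or a trifluoromethyl group at this place would stand apart from methoxy and chloro remains open. So does whether plain hydrogen there would give a number beyond the scatter of compound 2 and compound 3.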